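The source may hold more compounds than are shown below. What is called first, only, known or untested is meant among the compounds shown, and "the series" means these compounds.

Measured so far in a functional assay on MIA PaCa-2 cells (Homo sapiens) for inhibition, read by MTT assay, with a stated time of 7 days; a lower number here means a stronger inhibitor, a higher number a weaker inhibitor:
- compound 1 `CCN(CC)S(=O)(=O)c1ccc(S(=O)(=O)N2CCC[C@@H](C(=O)N3CCC(O)CC3)C2)cc1`: 870 nM
- compound 2 `CCN(CC)S(=O)(=O)c1ccc(S(=O)(=O)N2CCC[C@@H](C(=O)N3CCOCC3)C2)cc1`: 350 nM
- compound 3 `CCN(CC)S(=O)(=O)c1ccc(S(=O)(=O)N2CCC[C@@H](C(=O)N3CCC(C(F)(F)F)CC3)C2)cc1`: 320 nM

Compound 3 gives the lowest number of the three; its nearest neighbour is compound 2, and the two sit within the scatter of each other, so no order between them is claimed. Compound 1 stands apart: a 2.5-fold lower number from compound 1 to compound 2 (0.40 log units; beyond the scatter) and a 2.7-fold lower number from compound 1 to compound 3 (0.43 log units; beyond the scatter) are both beyond the scatter.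

Compound 4 `CCN(CC)S(=O)(=O)c1ccc(S(=O)(=O)N2CCC[C@@H](C(=O)N3CC[C@H](OC)C3)C2)cc1` differs from compound 3 in one place: 3-methoxypyrrolidin-1-yl in place of 4-(trifluoromethyl)piperidin-1-yl on a carbonyl carbon. Going by the values given here, two measured steps bear on it. a 1.1-fold lower number from compound 2 to compound 3 (0.04 log units; within the scatter) shows that swapping one amide ring for another without a donor left the number essentially unchanged. The steps out of compound 1 show that the only amide ring carrying a donor gave the weaker number. The entering ring has no donor and one acceptor, as does the ring of compound 2, so the expected step is none beyond the scatter, a 1.3-fold higher number from compound 3 to compound 4 (0.10 log units; within the scatter). The estimate for compound 4 in this assay is 400 nM, with a range of 180 nM to 900 nM.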

Compound 4, half-maximal inhibitory concentration: 2460 nM
Compound 4: the middle estimate sits 6.2-fold (0.79 log units) below what was measured, and the stated range ends below it.
By their numbers in this assay, from the lowest: compounds 3 and 2 (each within the scatter of the next); then compound 1; then compound 4.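

In this assay, the amide ring on the carbonyl carbon proves less interchangeable than compounds 2 and 3 suggested: 3-methoxypyrrolidin-1-yl gives a 7.7-fold higher number from compound 3 to compound 4 (0.89 log units; beyond the scatter) and a 7.0-fold higher number from compound 2 to compound 4 (0.85 log units; beyond the scatter). The ring also falls behind the one amide ring bearing a hydroxy group, with a 2.8-fold higher number from compound 1 to compound 4 (0.45 log units; beyond the scatter), so a ring without a hydrogen-bond donor can give the highest number in this set. No measurement available here accounts for the size of these steps.

Compound 4 changes ring size and substituent together, so the shown compounds do not separate the five-membered ring from the methoxy group as the source of the step. Unsubstituted pyrrolidin-1-yl, 4-methoxypiperidin-1-yl and the opposite stereoisomer of 3-methoxypyrrolidin-1-yl remain open comparisons.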